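Swapping Cyano for Nitro: Expected Cytotoxicity of Compound 4

This account rests on a few compounds, and the source may have more. Where it says the series, first, only, none or still open, it means among the compounds named here.

Compound 1 `C=C1CCC(c2csc(/C=C(\C)C(N)=O)c2)CC1`: in an ADME assay on NIH3T3 cells (Mus musculus) for cytotoxicity, read by CCK-8 assay, with a stated time of 24 h (on this read-out higher numbers stand for weaker inhibition and lower numbers for stronger inhibition), compound 1 gives > 50000 nM, a limit of the assay.
Compound 2 `C/C(=C\c1cc(-c2ccccc2)cs1)C(N)=O`: in this assay compound 2 gives > 50000 nM, again a limit.
Compound 3 `C/C(=C\c1cc(-c2ccc(C#N)cc2)cs1)C(N)=O`: in this assay compound 3 gives > 50000 nM, also a limit.

Compound 3 therefore stands where all measured compounds stand, at the limit of > 50000 nM in this assay, at which 3 of the 3 values shown sit; no compound has yet shown a real number in this assay. For the measured compounds named here, the only step between measured compounds, a step that the two limits leave unreadable from compound 2 to compound 3, runs between two limits and so has no readable size. Compound 4 `C/C(=C\c1cc(-c2ccc([N+](=O)[O-])cc2)cs1)C(N)=O` differs from compound 3 in a single place: nitro in place of cyano on an aromatic carbon. No measured step covers this exchange, so nothing shown points to a change in either direction. Going by the values given here, compound 4 is expected to sit at the limit as well because the limit of > 50000 nM in this assay, at which 3 of the 3 values shown sit, holds for every compound measured so far. For compound 4 the estimated value is 80000 nM, with a range from 30000 nM to 300000 nM, most likely reported only as a limit. The step this estimate means, a step that the limit leaves unreadable from compound 3 to compound 4, is expected to stay within the scatter.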

Compound 4, half-maximal inhibitory concentration: > 50000 nM
Compound 4: no number, only a limit; the forecaster's own chance of this, stated with the estimate: 85%; the middle value does not contradict the limit.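

For the compounds shown here, compound 4, like compound 2 and compound 3, gives only a limit in this assay, so no step from compound 2 or compound 3 to compound 4 can be read. The compounds shown leave open whether any change to the shared core would yield a real number, for all remain at one value: the limit of > 50000 nM in this assay, at which 4 of the 4 values shown sit.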